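A Hydroxy Group and Metabolic Stability in Mouse Microsomes

The source may report more compounds than this note shows. Statements on the series, on what has been measured and on what is new or still open speak of the compounds shown alone.

Of the compounds shown here, three have so far been measured in an ADME assay (liver, Mus musculus) for metabolic stability, using microsomes, with a stated time of 10 min; a lower number here means that less of the compound is left, a higher number that more of the compound is left.

Compound 1, `CCCc1cnc(N2CCC(C3Cc4cc(C5=CCN(S(=O)(=O)CCC)CC5)cc(F)c4O3)CC2)nc1`, gives 74%.
Compound 2, `CCCc1cnc(N2CCC(C3(C)Cc4cc(C5=CCN(S(=O)(=O)CCC)CC5)ccc4O3)CC2)nc1`, gives 52%.
Compound 3, `CCCc1cnc(N2CCC(C3Cc4cc(C5=CCN(S(=O)(=O)CCCO)CC5)cc(F)c4O3)CC2)nc1`, gives 60%.

Compound 1 and compound 3 share one core and differ in a single spot: hydroxy in place of hydrogen on a saturated chain carbon, three bonds along the chain from a sulfonyl sulfur. This change brings a number 14 percentage points lower from compound 1 to compound 3 (beyond the scatter), a loss that lies beyond the usual scatter of the measurement but is not dramatic. Compound 2 is built on a different core; how its core differs from that of compound 1 is not broken down here. Its number in this assay is the lowest of the three, though its gap to compound 3 stays within the scatter, while its gap to compound 1 lies beyond it.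

Compound 4, `CCCc1cnc(N2CCC(C3(C)Cc4cc(C5=CCN(S(=O)(=O)CCCO)CC5)ccc4O3)CC2)nc1`, has not yet been measured. It relates to compound 2 exactly as compound 3 relates to compound 1: hydroxy in place of hydrogen on a saturated chain carbon, three bonds along the chain from a sulfonyl sulfur. The place of the change is the same in both pairs, so this is the same change carried onto a second core.

Because compound 1 and compound 3 showed a number 14 percentage points lower from compound 1 to compound 3 (beyond the scatter), a downward step of about the same size is expected for the new pair. The expected step is a number 14 percentage points lower from compound 2 to compound 4 (beyond the scatter). Compound 4 is therefore estimated at 38% in this assay, most likely falling between 25% and 52%. This expectation rests on a single earlier pair and on the starting point of compound 2 alone, so it is tentative, and the measurement itself will show whether it holds.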

Compound 4, percent of the compound remaining: 42%
For compound 4 the middle estimate is 4 percentage points below the measured one; the range from low to high includes it.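

In this assay the hydroxy group on the second core gives a number 10 percentage points lower from compound 2 to compound 4 (within the scatter) and so, taken alone, this step cannot be told apart from the ordinary spread of repeated measurements. The result does not establish a rule for the series: two cores are only two cases, and neither pair tells what lies behind its step. Set side by side, the two steps show that the change carries over to the second core at a size that cannot be told apart from the size on the first core, which is a match within the limits of the measurement and not proof of an identical effect: the same change on two cores in this assay, a number 14 percentage points lower (beyond the scatter) from compound 1 to compound 3 and a number 10 percentage points lower (within the scatter) from compound 2 to compound 4, 4 percentage points apart, within the scatter of two such steps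

The compounds shown hold only propyl and 3-hydroxypropyl at this place, so it stays open how a longer chain bearing a hydroxy group, an amine or a carboxylic acid would read in this assay on either core. Going by these compounds, it also stays open whether hydroxy in place of hydrogen would give a step of similar size on a third core, where one more pair could test how far this match extends.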